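Methoxy to isopropyl on the aryl amide of the shared core

A few compounds are considered here, and "the series" means these few. Any claim that something is new, unique, unknown or untested is made for them only; others in the source may bear on it.

Compound 3 `COc1ccc(C(=O)N2CCN(Cc3nc4ccccc4n3Cc3cccc(C)c3)CC2)cc1` gives 55.5% in an assay on isolated protein for inhibition of aldehyde dehydrogenase 1A1 (Homo sapiens), read by spectrophotometry, tested at 10 uM (on this read-out lower numbers stand for less inhibition and higher numbers for more inhibition at the one concentration tested (going by the name of the read-out)), the second highest of three numbers. Compound 2 `CCC(=O)N1CCN(Cc2nc3ccccc3n2Cc2cccc(C)c2)CC1` gives 85.1%, and compound 1 `Cc1cccc(Cn2c(CN3CCN(C(=O)c4ccc([N+](=O)[O-])cc4)CC3)nc3ccccc32)c1` gives 24.3%. The steps to compound 3 were a number 31.2 percentage points higher from compound 1 to compound 3 (beyond the scatter) and a number 29.6 percentage points lower from compound 2 to compound 3 (beyond the scatter).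

Compound 4 `Cc1cccc(Cn2c(CN3CCN(C(=O)c4ccc(C(C)C)cc4)CC3)nc3ccccc32)c1` differs from compound 3 by isopropyl in place of methoxy on an aromatic carbon. Neither measured step exchanges one group for another on the aromatic ring while keeping the aryl amide; the nearest, a number 31.2 percentage points higher from compound 1 to compound 3 (beyond the scatter), replaces nitro rather than methoxy, so it bears only loosely. For the measured compounds named here, no step tests isopropyl at all. The expectation is therefore a change of at most modest size, a number 0.5 percentage points lower from compound 3 to compound 4 (within the scatter), with no firm direction.

Compound 4 is estimated at 55%, within 35% to 75%.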

Compound 4, a percentage reported as inhibition, at one concentration (the size of the read-out at that concentration, not a potency): 67.6%
Compound 4: middle estimate off by 12.6 percentage points, on the low side, and the stated range covers the measured number.
By their numbers in this assay, from the lowest: compound 1; then compound 3; then compound 4; then compound 2.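

In this assay the aryl amide does not cap out at methoxy: a number 12.1 percentage points higher from compound 3 to compound 4 (beyond the scatter) and a number 43.3 percentage points higher from compound 1 to compound 4 (beyond the scatter) put isopropyl above both methoxy and nitro at this place. The aryl amides shown still trail the ethyl amide, with a number 17.5 percentage points lower from compound 2 to compound 4 (beyond the scatter) as the closest approach so far. Nothing on hand accounts for this order of groups.

From the compounds shown here alone, whether an amine or a carboxylic acid on the same aromatic carbon would fall nearer isopropyl or nitro stays open. So does whether a longer chain on the carbonyl carbon would hold the level of compound 2.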